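Purine-substituted lactam ether series: methoxyphenethyl replacement

The compounds below may be only part of what the source reports. "The series", "measured", "known", "first", "only" and "open" are said of these compounds alone.

Measured compounds:
compound 1 `Cc1nn(-c2ncnc3nc[nH]c23)c2c1C(OCc1ccc(Cl)cc1Cl)CC(=O)N2` — 243 nM
compound 2 `Cc1cc(C)nc(-n2nc(C)c3c2NC(=O)CC3c2ccc(COc3cccc(Cl)c3)cc2)n1` — 3000 nM
compound 3 `Cc1cc(C)nc(-n2nc(C)c3c2NC(=O)CC3c2ccc(F)cc2F)n1` — a limit, > 10000 nM

In a functional assay on HEK293 cells for agonist activity at G-protein coupled receptor 39 (Homo sapiens), read by scintillation proximity assay and inositol phosphate accumulation, with a stated time of 75 min (a higher number here means that more compound is needed for the effect, a lower number that less compound is needed), compound 1 gives 243 nM. This is the lowest of the two numbers reported. The nearest number belongs to compound 2, which in this assay gives 3000 nM, a gap beyond the scatter. Compound 3 in this assay reaches only a limit, > 10000 nM; it is one of the values sitting at the limit of > 10000 nM in this assay, at which 1 of the 3 values shown sits. Within the data shown here, compounds 2 and 3 carry a different substituent on the shared core and a directly attached aryl group, so no single-change step is available between any two measured compounds, and only the raw numbers can be compared.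

Compound 4 `COc1ccc(CCOC2CC(=O)Nc3c2c(C)nn3-c2ncnc3nc[nH]c23)cc1` is not yet measured in this assay. It differs from compound 1 in one place: 4-methoxybenzyl in place of 2,4-dichlorophenyl on a saturated chain carbon bound to an oxygen on a saturated carbon. The change removes the two chlorines and adds an oxygen acceptor, and the aromatic ring moves one bond further from the ether oxygen. Among the measured compounds shown here, no measured pair shows the effect of either part of this change. Given the gap between compound 1 and the weaker compounds 2 and 3, a step to a higher number is expected for compound 4, of moderate size, a 4.9-fold higher number from compound 1 to compound 4 (0.69 log units; beyond the scatter). The estimate for compound 4 in this assay is 1200 nM, with a range from 250 nM to 6000 nM.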

Compound 4, half-maximal effective concentration: 70 nM
For compound 4 the middle estimate is 17-fold (1.23 log units) above the measured one, and the stated range ends above it.
By their numbers in this assay, from the lowest: compound 4; then compound 1; then compound 2. At a limit, above all of these: compound 3.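

In this assay, placing 4-methoxybenzyl in place of 2,4-dichlorophenyl on a saturated chain carbon bound to an oxygen on a saturated carbon gives a 3.5-fold lower number from compound 1 to compound 4 (0.54 log units; beyond the scatter). This single-change step shows that neither chlorine of the 2,4-dichlorobenzyl group is needed for a low number on this core, and that the position accepts the 2-(4-methoxyphenyl)ethyl group with its aromatic ring one bond further out. None of the supporting data shown bears on why the number falls with this change.

As far as these compounds go, the step bundles three differences: the loss of the chlorines, the gain of the methoxy group and the extra chain carbon, so their separate contributions remain open, and an unsubstituted 2-phenylethyl, a 2-(2,4-dichlorophenyl)ethyl or a 4-methoxybenzyl group on the ether oxygen would be needed to pull them apart. From the compounds shown here alone, how far the chain can extend also remains open, as does the outcome with a 3-(4-methoxyphenyl)propyl group or with a terminal amine or carboxylic acid at this position.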